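The source may report more compounds than this note shows. Statements on the series, on what has been measured and on what is new or still open speak of the compounds shown alone.

Measured compounds:
Compound 1 `CC1=C(C(=O)OC(C)(C)C)C(c2ccsc2)NC(=O)N1` — 15%
Compound 2 `CC1=C(C(=O)C2CC2)C(c2ccco2)NC(=O)N1` — 2%
Compound 3 `CC1=C(C(=O)C2CC2)C(c2cccs2)NC(=O)N1` — 1%

All three were tested in an assay on membranes from CHO cells for displacement of a labelled ligand from adenosine receptor A1 (Homo sapiens), read by scintillation counting, with a stated time of 60 min, tested at 1 uM; a lower number here means less inhibition, a higher number more inhibition at the concentration tested (going by the name of the read-out). Compound 3 gives the lowest of the three numbers. Its nearest neighbour is compound 2, and the step of a number 1 percentage points lower from compound 2 to compound 3 (within the scatter) lies within the scatter, so the two cannot be told apart. Compound 1 stands further away; its value and that of compound 3 differ by more than the scatter, but compound 1 also carries a tert-butyl ester where compounds 2 and 3 carry a cyclopropylcarbonyl group, so no single-change comparison links it to compound 3.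

Compound 4 `CC1=C(C(=O)C2CC2)C(c2ccsc2)NC(=O)N1` is the next compound. It differs from compound 3 in one place: thiophen-3-yl in place of thiophen-2-yl on a saturated ring carbon

Among the compounds with values here, the only measured step that bears on this change is the one from compound 2 to compound 3, which also swapped one five-membered aromatic ring for another on the same saturated ring carbon and stayed within the scatter. On that basis the expected step of a number 3 percentage points higher from compound 3 to compound 4 (within the scatter) is small, with no clear direction beyond the scatter. Compound 4 is therefore expected to give about 4% in this assay, estimated to fall between 0% and 14%.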

Compound 4, a percentage reported as inhibition, at one concentration (the size of the read-out at that concentration, not a potency): 2%
Compound 4: middle estimate off by 2 percentage points, on the high side; low and high end bracket the measured number.
By their numbers in this assay, from the lowest: compounds 3, 2 and 4 (each within the scatter of the next); then compound 1.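

With the cyclopropylcarbonyl group held constant, thiophen-3-yl in place of thiophen-2-yl gives a number 1 percentage points higher from compound 3 to compound 4 (within the scatter) in this assay, and thiophen-3-yl in place of furan-2-yl gives no change at the digits printed from compound 2 to compound 4 (within the scatter), so among these three compounds neither the thiophene attachment point nor the choice of ring registers in this read-out. Compound 4 also provides the first single-change link to compound 1, as both carry thiophen-3-yl: cyclopropyl in place of tert-butoxy on the carbonyl carbon gives a number 13 percentage points lower from compound 1 to compound 4 (beyond the scatter), which shows that the group on the carbonyl carbon can shift the number by more than the ring changes have so far. Nothing available explains this difference.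

On these data alone, it remains open whether tert-butoxy would give a similar step alongside furan-2-yl or thiophen-2-yl, and what an ethoxy group or a longer chain on the carbonyl carbon would give. Also unknown is whether a phenyl ring or a ring bearing an amine on the saturated ring carbon would move the number beyond the scatter, where the five-membered aromatic rings here do not.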